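Methoxy to hydroxy on the aromatic ring of compound 3

The source may report more compounds than this note shows. Statements on the series, on what has been measured and on what is new or still open speak of the compounds shown alone.

Values in a functional assay on MCF7 cells (Homo sapiens) for cytotoxicity, read by MTT assay, with a stated time of 72 h (on this read-out higher numbers stand for weaker inhibition and lower numbers for stronger inhibition), so far
compound 1 `COc1cccc(/C=C2\CCC/C(=C\c3ccccc3Cl)C2=O)c1OC` gives 11300 nM
compound 2 `COc1cccc(/C=C2\CCC/C(=C\c3cccc(OC)c3OC)C2=O)c1` gives 5900 nM
compound 3 `COc1cc(/C=C2\CCC/C(=C\c3cccc(OC)c3OC)C2=O)ccc1O` gives 11600 nM

Compound 3 has no separate place among these numbers, since its value lies within the scatter of both others. The next compound is compound 4 `COc1cccc(/C=C2\CCC/C(=C\c3ccc(O)c(O)c3)C2=O)c1OC` and the change is hydrogen in place of methyl on an oxygen on an aromatic ring in which hydrogen takes the place of methyl on an oxygen on an aromatic ring, turning 4-hydroxy-3-methoxyphenyl into 3,4-dihydroxyphenyl.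

Within the data shown here, no measured step makes this exact change. The closest is a 2.0-fold higher number from compound 2 to compound 3 (0.29 log units; within the scatter) for hydroxy in place of hydrogen on an aromatic carbon. The two exchanges of the 2-chlorophenyl group are also small: a 1.9-fold lower number from compound 1 to compound 2 (0.28 log units; within the scatter) and a 1.0-fold higher number from compound 1 to compound 3 (0.01 log units; within the scatter) both stay inside the scatter. Among the measured compounds shown here, with only three compounds, this is thin support, but nothing here points to a large step and the direction remains open. The estimate is a 1.3-fold lower number from compound 3 to compound 4 (0.11 log units; within the scatter) and no step beyond the scatter is expected. Expected for compound 4 is 9000 nM with 3500 nM to 20000 nM as its estimated range.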

Compound 4, half-maximal inhibitory concentration: 4700 nM
Beside the measured number, compound 4's estimate is 1.9-fold (0.28 log units) above it; low and high end bracket the measured number.
By their numbers in this assay, from the lowest: compounds 4, 2, 1 and 3 (each within the scatter of the next, the first and the last beyond it).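

In this assay, among these compounds, the methoxy to hydroxy exchange that turns 4-hydroxy-3-methoxyphenyl into 3,4-dihydroxyphenyl gives a 2.5-fold lower number from compound 3 to compound 4 (0.39 log units; beyond the scatter) and is the first step to pass the scatter, all earlier steps having stayed inside it. The 3,4-dihydroxyphenyl group also separates from 2-chlorophenyl, with a 2.4-fold lower number from compound 1 to compound 4 (0.38 log units; beyond the scatter) on that exchange, but not from 3-methoxyphenyl, with a 1.3-fold lower number from compound 2 to compound 4 (0.10 log units; within the scatter) for that pair, so compound 2 goes against any reading that 3,4-dihydroxyphenyl stands apart from all the groups tried at this place. No measurement in hand bears on why the methoxy to hydroxy step has this size.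

Still open, from the compounds shown here alone, is whether an amino group or a carboxylic acid in place of the hydroxy on this aromatic ring would hold the number or lose it. Also open, going by these compounds, is whether the same methoxy to hydroxy exchange gives a step of similar size when made on the other aromatic ring of the shared core, since one modest step at one place says nothing about a second place.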